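Bromo in Place of Fluoro: Two Measured, One Pending

The source may hold more compounds than are shown below. What is called first, only, known or untested is meant among the compounds shown, and "the series" means these compounds.

Compound 1 `O=S(=O)(/C=C/c1ccc(F)cc1)Cc1ccc(Nc2ncnc3ccccc23)cc1`: 10 nM
Compound 2 `O=S(=O)(/C=C/c1ccc(Br)cc1)Cc1ccc(Nc2ncnc3ccccc23)cc1`: a limit, > 100000 nM
Compound 3 `COc1cc2ncnc(Nc3ccc(CS(=O)(=O)/C=C/c4ccc(F)cc4)cc3)c2cc1OC`: a limit, > 100000 nM

In a functional assay on U-251 cells (Homo sapiens) (on this read-out lower numbers stand for stronger inhibition of growth and higher numbers for weaker inhibition of growth), compound 1 gives 10 nM. For compound 2 only a limit is reported, > 100000 nM. The change bromo in place of fluoro on an aromatic carbon therefore produced an at least 10000-fold higher number from compound 1 to compound 2 (4.00 log units; beyond the scatter). Compound 3 carries the same fluoro-bearing side chain as compound 1 but a different core; the difference between the two cores is not broken down here. For compound 3 as well only a limit is reported, > 100000 nM. Two of the three values thus sit at the limit of > 100000 nM in this assay, at which 2 of the 3 values shown sit.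

Compound 4 `COc1cc2ncnc(Nc3ccc(CS(=O)(=O)/C=C/c4ccc(Br)cc4)cc3)c2cc1OC` has not yet been measured in this assay. It arises from compound 3 by bromo in place of fluoro on an aromatic carbon, the same change made from compound 1 to compound 2. Because that change gave an at least 10000-fold higher number from compound 1 to compound 2 (4.00 log units; beyond the scatter), and compound 3 already stands at a limit, compound 4 is expected to give 100000 nM, with a range from 30000 nM to 100000 nM. The expected step is a number no higher from compound 3 to compound 4 (the limit leaves the size open).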

Compound 4, concentration for 50% growth inhibition: 11000 nM
For compound 4 the middle estimate is 9.1-fold (0.96 log units) above the measured one; the measured number lies below the stated range.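

In this assay, bromo in place of fluoro on an aromatic carbon gave an at least 9.0-fold lower number from compound 3 to compound 4 (0.95 log units; beyond the scatter), a step that starts from a limit for compound 3. The change therefore did not carry over from one core to the other, and the two steps run in opposite directions: the same change on two cores in this assay, an at least 10000-fold higher number (4.00 log units; beyond the scatter) from compound 1 to compound 2 and an at least 9.0-fold lower number (0.95 log units; beyond the scatter) from compound 3 to compound 4, at least 90000-fold (4.95 log units) apart, beyond the scatter of two such steps. This shows a clear difference between these two pairs, but each step has a limit at one end, so neither size is exact, and two pairs set no rule for the series.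

The compounds shown leave open whether chloro or a nitrile in the same place would follow fluoro or bromo on either core. They also leave open which part of the difference between the two cores matters.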